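A few compounds are considered here, and "the series" means these few. Any claim that something is new, unique, unknown or untested is made for them only; others in the source may bear on it.

Of the compounds shown here, three with a shared core have been measured, and a fourth waits. Compound 1, `Cc1cccc(C#Cc2nc3c(s2)C(=O)NCC3)c1`, gives in an assay on HEK293 cells for negative allosteric modulation of metabotropic glutamate receptor 5 (Homo sapiens), read by FLIPR, with a stated time of 1 h (a lower number here means a stronger inhibitor, a higher number a weaker inhibitor), only a limit, > 10000 nM, and this is one of the values that sits at the limit of the measurement (the limit of > 10000 nM in this assay, at which 1 of the 3 values shown sits). Compound 2, `O=C1c2sc(C#Cc3ccccc3)nc2CN1C1CC1`, gives in this assay a value of 23 nM. Compound 3, `CC(=O)N1CCc2nc(C#Cc3ccccc3)sc2C1`, gives in this assay a value of 90 nM, which is the higher of the two numbers shown, with compound 2 as its nearest neighbour at a gap that is beyond the usual scatter.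

Compound 4, `CC1CCC(C(=O)N2CCc3nc(C#Cc4ccccc4)sc3C2)CC1`, has not yet been measured. It differs from compound 3 in one place: 4-methylcyclohexyl in place of methyl on a carbonyl carbon. For the measured compounds named here, no measured pair in this set shows a change of this kind, so the size of the step is open. The author expects the number in this assay to move only modestly, if at all, and more likely upward than downward, so that the expected step from compound 3 to compound 4 is a 1.7-fold higher number from compound 3 to compound 4 (0.22 log units; within the scatter). Compound 4 is therefore estimated to give in this assay a value near 150 nM, with a plausible range from 30 nM to 800 nM.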

Compound 4, half-maximal inhibitory concentration: > 10000 nM
Compound 4 was reported as a limit; the forecaster's own chance of this, stated with the estimate: 10%; middle value at least 66-fold (1.82 log units) away from the limit.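

For the compounds shown here, on the carbonyl carbon, 4-methylcyclohexyl in place of methyl gives an at least 110-fold higher number from compound 3 to compound 4 (2.04 log units; beyond the scatter) in this assay, the first single change in this set that can be read. Going by these compounds alone, the activity seen with methyl at this place does not survive the larger group, so this position is far from indifferent to what it carries, a point that the earlier compounds, which differ from each other in more than one place, could not show. In this assay compound 4 gives > 10000 nM, which is a limit and not a number, so the step is a bound and its full size stays unknown: the limit of > 10000 nM in this assay, at which 2 of the 4 values shown sit.

The compounds shown leave open whether the loss follows from the ring, from its methyl or from the carbon count alone, which ethyl or plain cyclohexyl on the same carbonyl carbon would separate. They also leave open how an amine or a hydroxyl on such a group would read.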